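Rearranging the Chlorines on the Dichlorophenyl Group

The compounds below may be only part of what the source reports. "The series", "measured", "known", "first", "only" and "open" are said of these compounds alone.

Compound 1 `Nc1scc(CN2CCN(c3ccc(F)cc3F)CC2)c1C(=O)c1ccc(Cl)cc1` and compound 2 `Nc1scc(CN2CCN(c3c(Cl)cccc3Cl)CC2)c1C(=O)c1ccc(Cl)cc1` share one core and differ only in the aryl group on an amine nitrogen in a ring. In an assay on CHO cells for displacement of a labelled ligand from adenosine receptor A3 (Homo sapiens), read by scintillation counting, with a stated time of 120 min, tested at 10 uM (a lower number here means less inhibition, a higher number more inhibition at the concentration tested (going by the name of the read-out)), compound 1 gives 0% and compound 2 gives 1%. The step of a number 1 percentage points higher from compound 1 to compound 2 (within the scatter) is within the scatter, so the two read alike. For the measured compounds named here, compound 2 thus holds the higher of only two numbers, with compound 1 within the scatter of it, which gives no ordering. Compound 3 `Nc1scc(CN2CCN(c3ccc(Cl)c(Cl)c3)CC2)c1C(=O)c1ccc(Cl)cc1` has the same atoms as compound 2 joined differently: 3,4-dichlorophenyl in place of 2,6-dichlorophenyl on an amine nitrogen in a ring. Going by the values given here, the only measured step, the aryl swap from compound 1 to compound 2, moved nothing beyond the scatter, and no measured step involves 3,4-dichlorophenyl at all. Compound 3 is therefore expected to read at the same low level. The expected step is a number 1 percentage points higher from compound 2 to compound 3 (within the scatter), nothing beyond the scatter. Compound 3 is estimated at 2%, between 0% and 15%.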

Compound 3, a percentage reported as inhibition, at one concentration (the size of the read-out at that concentration, not a potency): 3%
The estimate for compound 3 lay 1 percentage points below the measured number, within the range that was stated.
By their numbers in this assay, from the lowest: compounds 1, 2 and 3 (each within the scatter of the next).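

The step of a number 2 percentage points higher from compound 2 to compound 3 (within the scatter) rearranges the same atoms, and the step of a number 3 percentage points higher from compound 1 to compound 3 (within the scatter) changes both the halogen and its placement on the ring. At this position, on an amine nitrogen in a ring, three halogenated phenyl groups now read alike in this assay, so moving the two chlorines from 2,6-dichlorophenyl to 3,4-dichlorophenyl leaves the read-out within the scatter. Nothing available explains this flat result.

From the compounds shown here alone, it remains open whether a phenyl ring carrying an amine or a carboxylic acid in place of the halogens would lift the read-out beyond the scatter. Going by these compounds, it is equally open whether any change elsewhere on the shared core would do so.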